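Swapping Fluorophenyl for Pyridinyl on a Urea Antagonist

A few compounds are considered here, and "the series" means these few. Any claim that something is new, unique, unknown or untested is made for them only; others in the source may bear on it.

Going by the values given here, in an assay on CHO cells for antagonist activity at transient receptor potential cation channel subfamily M member 8 (Rattus norvegicus), read by luminescence and calcium flux, with a stated time of 2.5 min (on this read-out higher numbers stand for weaker inhibition and lower numbers for stronger inhibition), compound 1 `O=C(Nc1ccc(F)cc1)N1CCc2cccnc2[C@H]1c1ccc(C(F)(F)F)cc1` gives 37 nM, the lowest of the three numbers measured so far. Compound 3 `O=C(Nc1ccc(F)cc1)N1CCc2nccnc2[C@H]1c1ccc(C(F)(F)F)cc1` gives 350 nM, and compound 2 `O=C(Nc1ccc(F)cc1)N1CCc2cncnc2C1c1ccc(C(F)(F)F)cc1` gives 1170 nM; each of these two gaps to compound 1 lies beyond the usual scatter of the assay. Compound 4 `O=C(Nc1cccnc1)N1CCc2cccnc2[C@H]1c1ccc(C(F)(F)F)cc1` has not yet been measured in this assay. It differs from compound 1 in a single place: pyridin-3-yl in place of 4-fluorophenyl on an amide-type nitrogen. Among the compounds with values here, no measured pair of compounds carries this same change, so nothing in the present numbers shows how it plays out. A modest weakening is expected, roughly a 3.0-fold higher number from compound 1 to compound 4 (0.47 log units; beyond the scatter), smaller than the gaps seen between the three measured compounds. Compound 4 is therefore estimated to give 110 nM, with a likely range from 30 nM to 400 nM.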

Compound 4, half-maximal inhibitory concentration: 48 nM
Compound 4: middle estimate off by 2.3-fold (0.36 log units), on the high side; the range from low to high includes it.
By their numbers in this assay, from the lowest: compounds 1 and 4 (each within the scatter of the next); then compound 3; then compound 2.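

In this assay, placing pyridin-3-yl instead of 4-fluorophenyl on the amide-type nitrogen gives a 1.3-fold higher number from compound 1 to compound 4 (0.11 log units; within the scatter). Going by these compounds alone, the first three compounds all carry 4-fluorophenyl, so only this pair shows that the place tolerates a ring containing nitrogen and no fluorine, with the two compounds indistinguishable in this test. Nothing available explains why the two groups read alike.

On these data alone, whether this place needs an aromatic ring at all remains open, and a cyclohexyl group or a plain methyl would test that. Whether pyridin-3-yl behaves the same way on the cores of compound 2 and compound 3 is also unknown.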